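Swapping fluorine for a nitrile on the pendant ring

A few compounds are considered here, and "the series" means these few. Any claim that something is new, unique, unknown or untested is made for them only; others in the source may bear on it.

Three compounds sharing one core carry a halogen on the pendant ring: compound 1 `O=c1ccoc2ccc(OCc3cccc(Cl)c3)cc12`, compound 2 `O=c1ccoc2ccc(OCc3cccc(Br)c3)cc12` and compound 3 `O=c1ccoc2ccc(OCc3cccc(F)c3)cc12`. In an assay on microsomes for inhibition of Amine oxidase [flavin-containing] B (Homo sapiens), read by fluorescence and spectrophotometry, with a stated time of 20 min (a higher number here means a weaker inhibitor, a lower number a stronger inhibitor), compound 1 gives 3.6 nM, compound 2 gives 2 nM and compound 3 gives 13 nM, the highest of the three numbers. The fluoro compound sits furthest from the others: a 3.6-fold higher number from compound 1 to compound 3 (0.56 log units; beyond the scatter) and a 6.5-fold higher number from compound 2 to compound 3 (0.81 log units; beyond the scatter), while a 1.8-fold lower number from compound 1 to compound 2 (0.26 log units; within the scatter). Compound 4 `N#Cc1cccc(COc2ccc3occc(=O)c3c2)c1` changes compound 3 by cyano in place of fluoro on an aromatic carbon. Among the measured compounds shown here, no measured step touches a cyano group, so the halogen steps give only a loose guide. Compound 4 is expected to show 9 nM in this assay, with a range from 2.5 nM to 30 nM. This estimate means a step of a 1.4-fold lower number from compound 3 to compound 4 (0.16 log units; within the scatter), expected to be small.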

Compound 4, half-maximal inhibitory concentration: 76 nM
Compound 4: the middle estimate sits 8.4-fold (0.93 log units) below what was measured; measured number above the stated range.
By their numbers in this assay, from the lowest: compounds 2 and 1 (each within the scatter of the next); then compound 3; then compound 4.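

In this assay, among the compounds shown here, cyano is the first group here to break from the halogens at this place on the pendant ring, with a clear rise even against the weakest halogen compound (a 5.8-fold higher number from compound 3 to compound 4 (0.77 log units; beyond the scatter)). The gap is larger against the other two (a 21-fold higher number from compound 1 to compound 4 (1.32 log units; beyond the scatter); a 38-fold higher number from compound 2 to compound 4 (1.58 log units; beyond the scatter)), so among these four compounds, this position does not accept every small group alike. Nothing available explains this rise.

From the compounds shown here alone, whether an amine or a carboxylic acid here would track the halogens or cyano remains open. So does whether cyano has the same effect elsewhere on the pendant ring.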